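Swapping a thiophene for a fluorinated cyclohexene ring

This account rests on a few compounds, and the source may have more. Where it says the series, first, only, none or still open, it means among the compounds named here.

Of the compounds shown here, three sharing one core have been measured in a physicochemical assay for solubility, read by HPLC, using the shake flask method, measured as kinetic solubility, with a stated time of 2 h, at pH 7.4; a lower number here means a less soluble compound, a higher number a more soluble compound. Compound 1 `Cc1cc(NCc2ccccn2)n2ncc(-c3cccc(F)c3)c2n1` gives 5000 nM, compound 2 `Cc1cc(NCc2ccccn2)n2ncc(-c3ccccc3F)c2n1` gives 5000 nM, and compound 3 `Cc1cc(NCc2ccccn2)n2ncc(-c3ccsc3)c2n1` gives 9000 nM. Compound 3 sits at the upper end of these numbers, but the steps of a 1.8-fold higher number from compound 1 to compound 3 (0.26 log units; within the scatter) and a 1.8-fold higher number from compound 2 to compound 3 (0.26 log units; within the scatter) are both within the scatter, as is no change at the digits printed from compound 1 to compound 2 (within the scatter). Compound 4 `Cc1cc(NCc2ccccn2)n2ncc(C3=CCC(F)(F)CC3)c2n1` differs from compound 3 in one place: 4,4-difluorocyclohex-1-en-1-yl in place of thiophen-3-yl on an aromatic carbon. Within the data shown here, none of the measured steps replaces an aromatic ring with a non-aromatic one, so they offer only a weak guide; all three were small, and a step of similar size is expected here, a 1.3-fold lower number from compound 3 to compound 4 (0.11 log units; within the scatter). Compound 4 is therefore estimated at 7000 nM, with a range from 2500 nM to 20000 nM.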

Compound 4, solubility: 5000 nM
The estimate for compound 4 lay 1.4-fold (0.15 log units) above the measured number, and the stated range covers the measured number.
By their numbers in this assay, from the lowest: compounds 1, 2, 4 and 3 (each within the scatter of the next).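

At this position, on an aromatic carbon of the five-membered ring, a non-aromatic ring of carbon only, 4,4-difluorocyclohex-1-en-1-yl, now joins the aromatic groups, and every step stays small in this assay: a 1.8-fold lower number from compound 3 to compound 4 (0.26 log units; within the scatter), no change at the digits printed from compound 2 to compound 4 (within the scatter) and no change at the digits printed from compound 1 to compound 4 (within the scatter). Ring aromaticity at this position therefore makes no difference that this assay can separate among these compounds. No measurement shown here offers an explanation for this result. Still open, going by these compounds, is whether a group of another kind at this position, such as an amine or a carboxylic acid, would give a step beyond the scatter.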